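Anilinoquinazoline series: cytotoxicity on U-937 cells, regioisomer step

The source may report more compounds than this note shows. Statements on the series, on what has been measured and on what is new or still open speak of the compounds shown alone.

Measured compounds:
compound 1 `Fc1ccc(Nc2nc(-c3cccc(F)c3)nc3ccc(F)cc23)cc1`: > 50000 nM (a limit, not a number)
compound 2 `Fc1cccc(-c2nc(Nc3cccc(Br)c3)c3cc(F)ccc3n2)c1`: > 50000 nM (a limit, not a number)
compound 3 `Nc1cccc(Nc2nc(-c3cccc(F)c3)nc3ccc(F)cc23)c1`: > 50000 nM (a limit, not a number)

For the measured compounds named here, in a functional assay on U-937 cells (Homo sapiens) for cytotoxicity, read by MTT assay, with a stated time of 48 h (on this read-out higher numbers stand for weaker inhibition and lower numbers for stronger inhibition), every value so far is a limit rather than a number. Compound 3 stands at that limit together with the other two, so no ranking among them can be read (the limit of > 50000 nM in this assay, at which 3 of the 3 values shown sit). The steps from compound 1 to compound 2 a step that the two limits leave unreadable from compound 1 to compound 2, from compound 1 to compound 3 a step that the two limits leave unreadable from compound 1 to compound 3 and from compound 2 to compound 3 a step that the two limits leave unreadable from compound 2 to compound 3 are all unreadable in size for the same reason: both ends are limits.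

Compound 4 `Nc1ccccc1Nc1nc(-c2cccc(F)c2)nc2ccc(F)cc12` differs from compound 3 by 2-aminophenyl in place of 3-aminophenyl on a nitrogen on an aromatic ring. The measured steps bear on it only in that changes on the same nitrogen-borne phenyl ring, whatever their kind, have left every compound at the limit. No readable step exists, so no direction beyond the scatter is expected: the step from compound 3 to compound 4 is estimated as a step that the limit leaves unreadable from compound 3 to compound 4. Compound 4 is expected to give 80000 nM in this assay, between 30000 nM and 300000 nM, most likely reported as a limit again.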

Compound 4, half-maximal inhibitory concentration: 47300 nM
Beside the measured number, compound 4's estimate is 1.7-fold (0.23 log units) above it; the range from low to high includes it.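

In this assay compound 4 gives 47300 nM, the only value so far that is a number rather than a limit: the limit of > 50000 nM in this assay, at which 3 of the 4 values shown sit.

With 2-aminophenyl in place of 3-aminophenyl on the nitrogen, the data give an at least 1.0-fold lower number from compound 3 to compound 4 (0.02 log units; that floor lies within the scatter), and the same group on that nitrogen gives an at least 1.0-fold lower number from compound 2 to compound 4 (0.02 log units; that floor lies within the scatter) and an at least 1.0-fold lower number from compound 1 to compound 4 (0.02 log units; that floor lies within the scatter). All three floors lie within the scatter, so this position can now be said to yield a readable value in this assay, but no real change from any of the other three compounds can be claimed.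

Going by these compounds, the true distance of compound 1, compound 2 and compound 3 from compound 4 remains open. Also open, on these data alone, is whether a hydroxyl or a carboxylic acid in place of the amino group of 2-aminophenyl would give a number in this assay.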